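This account rests on a few compounds, and the source may have more. Where it says the series, first, only, none or still open, it means among the compounds named here.

Compound 1 `Cc1nnsc1CO/N=C/c1c(C)nn(C)c1Oc1ccc(F)cc1`: > 50000 nM
Compound 2 `CCCc1nnsc1CO/N=C/c1c(C)nn(C)c1Oc1ccccc1Cl`: 17600 nM

In a functional assay on SGC-7901 cells (Homo sapiens) for inhibition, read by MTT assay, with a stated time of 48 h (on this read-out lower numbers stand for stronger inhibition and higher numbers for weaker inhibition), compound 2 gives 17600 nM. For compound 1 this assay reports only a limit, > 50000 nM, and no number is known for it. For the measured compounds named here, compound 2 therefore holds the only actual number among the two values shown, the other being a limit, as noted in the limit of > 50000 nM in this assay, at which 1 of the 2 values shown sits. Compound 3 `CCCc1nnsc1CO/N=C/c1c(C)nn(C)c1Oc1ccc(F)cc1` differs from compound 2 in a single place: 4-fluorophenyl in place of 2-chlorophenyl on an oxygen on an aromatic ring. No measured pair differs by exactly this change, so the expectation rests on what is shown: compound 1 carries the same 4-fluorophenyl group and sits at the limit, though it also differs from compound 2 in another place. Compound 3 is expected to be weaker, with the step from compound 2 to compound 3 estimated at a 2.3-fold higher number from compound 2 to compound 3 (0.36 log units; beyond the scatter), beyond the scatter and possibly reaching the limit. The estimate for compound 3 is 40000 nM, within 15000 nM to 100000 nM.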

Compound 3, half-maximal inhibitory concentration: 8640 nM
For compound 3 the middle estimate is 4.6-fold (0.67 log units) above the measured one; the measured number lies below the stated range.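

In this assay, a 2.0-fold lower number from compound 2 to compound 3 (0.31 log units; beyond the scatter) shows that the group on this oxygen affects the read-out, with 4-fluorophenyl giving the lower number and so the stronger inhibition of the pair. Compound 1, which carries the same 4-fluorophenyl group, is reported only as a limit and not as a number: the limit of > 50000 nM in this assay, at which 1 of the 3 values shown sits. With 4-fluorophenyl held constant, placing ethyl in place of hydrogen on a saturated chain carbon bound to an aromatic carbon gives an at least 5.7-fold lower number from compound 1 to compound 3 (0.76 log units; beyond the scatter), so this group alone does not keep a compound at the limit.

This swap changes both the halogen and its place on the ring, so the two effects cannot be separated here. From the compounds shown here alone, how a 4-chlorophenyl or plain phenyl group would behave on this oxygen remains open, as does the effect of a longer chain.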